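The compounds below may be only part of what the source reports. "The series", "measured", "known", "first", "only" and "open" are said of these compounds alone.

Compound 1, `O=C(Nc1ccc(S(=O)(=O)Nc2ccccc2)cc1)c1cc(F)c(Cl)cc1F`, gives 37% in a functional assay on HEK293 cells for agonist activity at probable G-protein coupled receptor 27 (Homo sapiens), read by a luciferase reporter and beta-arrestin recruitment, with a stated time of 10 min; a lower number here means a smaller maximal response, a higher number a larger maximal response.
Compound 2, `O=C(Nc1ccc(S(=O)(=O)Nc2ccccc2)cc1)c1ccc(Br)cc1F`, gives 67% in this assay.

Among these two numbers compound 2 stands highest; its only neighbour is compound 1, and the step of a number 30 percentage points higher from compound 1 to compound 2 (beyond the scatter) lies beyond the scatter. That single step is the only one measured, and it alters the ring on the carbonyl carbon in two places at once, so it bears on what follows only loosely: it shows that a change on this ring can shift the maximal response by a modest amount, but nothing more.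

Compound 3, `N#Cc1ccc(C(=O)Nc2ccc(S(=O)(=O)Nc3ccccc3)cc2)c(F)c1`, has not yet been tested in this assay. It differs from compound 2 by cyano in place of bromo on an aromatic carbon. Among the compounds with values here, no measured pair shows cyano taking the place of bromo, so the direction of this step is open, and a modest step either way seems about as likely as none beyond the scatter. Weighing this, the estimate for compound 3 in this assay is 52%, expected to fall between 25% and 80%. That estimate corresponds to an expected step of a number 15 percentage points lower from compound 2 to compound 3 (beyond the scatter).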

Compound 3, largest response reached (Emax), in percent of the reference or control that the assay uses: 29%
Compound 3: middle estimate off by 23 percentage points, on the high side, and the stated range covers the measured number.
By their numbers in this assay, from the lowest: compounds 3 and 1 (each within the scatter of the next); then compound 2.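

In this assay, the position that holds bromo in compound 2 can move the maximal response on its own: with cyano in place of bromo and the fluoro group and the rest of the core unchanged, the response is a number 38 percentage points lower from compound 2 to compound 3 (beyond the scatter). Within the data shown here, the earlier pair altered this ring in two places at once and could not tie a shift to a single position, whereas this exchange touches only the one position, and its step is large rather than modest. The response is also a number 8 percentage points lower from compound 1 to compound 3 (within the scatter), so 4-cyano-2-fluorophenyl and 4-chloro-2,5-difluorophenyl on the carbonyl carbon do not separate here, and among these three compounds only 4-bromo-2-fluorophenyl stands apart from the others.

Nothing given here speaks to why bromo and cyano differ at this position.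

From the compounds shown here alone, it also remains open whether the larger response belongs to bromo alone or would also appear with iodo, methoxy, an amine or a carboxylic acid at the same place on the ring.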